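Solubility notes: carboxy to oxadiazole on the shared core

A few compounds are considered here, and "the series" means these few. Any claim that something is new, unique, unknown or untested is made for them only; others in the source may bear on it.

Measured so far:
compound 1 `Cc1nc(C(=O)O)c(N)c2c1C(=O)N(Cc1ccccc1)C2=O` gives 177000 nM
compound 2 `COC(=O)c1nc(C)c2c(c1N)C(=O)N(Cc1ccccc1)C2=O` gives 7400 nM

In a physicochemical assay for solubility, using the shake flask method, in simulated intestinal fluid, measured as kinetic solubility, with a stated time of 2 h, at 25 degrees C, at pH 6.5 (on this read-out lower numbers stand for lower solubility and higher numbers for higher solubility), compound 1 stands highest of the two numbers; the nearest, compound 2, lies a 24-fold lower number from compound 1 to compound 2 (1.38 log units; beyond the scatter) below it. For the measured compounds named here, that single step, methyl in place of hydrogen on an oxygen next to a carbonyl group, is the only measured change on the core so far, and it is large.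

Compound 3 `Cc1nnc(-c2nc(C)c3c(c2N)C(=O)N(Cc2ccccc2)C3=O)o1` differs from compound 1 by 5-methyl-1,3,4-oxadiazol-2-yl in place of carboxy on an aromatic carbon. Going by the values given here, as with compound 2, the carboxy of compound 1 is gone, so the step from compound 1 to compound 2 is the one measured step that bears on this change, and it was large. Among the compounds with values here, no measured pair carries the 5-methyl-1,3,4-oxadiazol-2-yl itself, so its own contribution is unknown; the expectation rests on the loss of carboxy alone.

For this assay compound 3 is therefore expected to fall clearly below compound 1, by about a 22-fold lower number from compound 1 to compound 3 (1.34 log units; beyond the scatter), in the direction of compound 2. The estimate for compound 3 is 8000 nM, with a range of 2000 nM to 30000 nM.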

Compound 3, solubility: < 5000 nM
Compound 3 gave a limit, no number (the forecaster's own chance of this, stated with the estimate: 5%); middle value at least 1.6-fold (0.20 log units) away from the limit.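

Compound 3 returns a limit and not a number in this assay: the limit of < 5000 nM in this assay, at which 1 of the 3 values shown sits. Even so, the step to 5-methyl-1,3,4-oxadiazol-2-yl on this aromatic carbon can be read as an at least 35-fold lower number from compound 1 to compound 3 (1.54 log units; beyond the scatter), so a second replacement of carboxy, this time by a five-membered aromatic ring, also ends far under the carboxy compound, and neither of the two replacements shown goes against this. The other step, from methoxycarbonyl to the oxadiazole at the same place, reads as an at least 1.4-fold lower number from compound 2 to compound 3 (0.17 log units; that floor lies within the scatter), and since that floor lies within the scatter, no order can be drawn between these two replacements.

Still open, on these data alone, is where the true value of compound 3 lies under its limit, and with it whether the oxadiazole and the methoxycarbonyl differ at all in this read-out. As far as these compounds go, it is also open whether a group such as a primary carboxamide or an aminomethyl on this aromatic carbon would stay close to compound 1 or fall with compound 2 and compound 3, which would help separate the loss of carboxy from the contribution of the group that enters.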